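Benzyl substituent swap in a sulfonyl-dihydropyran series

The source may report more compounds than this note shows. Statements on the series, on what has been measured and on what is new or still open speak of the compounds shown alone.

Compound 1 `CC1(Cc2cccc(/C(N)=N/O)c2)CC(S(=O)(=O)c2ccc(F)cc2)=C(c2ccc(/C(N)=N/O)cc2)O1` and compound 2 `CC1(Cc2cccc(C(F)(F)F)c2)CC(S(=O)(=O)c2ccc(F)cc2)=C(c2ccc(/C(N)=N/O)cc2)O1` form the measured pair. In an ADME assay on cells (Peritoneal macrophage, Mus musculus, strain Balb/c) for cytotoxicity, read by resazurin assay, with a stated time of 72 h (on this read-out higher numbers stand for lower toxicity in this test and lower numbers for higher toxicity in this test), compound 1 gives 50200 nM; compound 2 gives 49800 nM, so compound 2 sits level with compound 1, the step of a 1.0-fold lower number from compound 1 to compound 2 (0.00 log units; within the scatter) lying within the scatter. Compound 3 `CC1(Cc2ccc([N+](=O)[O-])cc2)CC(S(=O)(=O)c2ccc(F)cc2)=C(c2ccc(/C(N)=N/O)cc2)O1` carries 4-nitrophenyl in place of 3-(trifluoromethyl)phenyl on a saturated chain carbon bound to a saturated ring carbon. Among the measured compounds shown here, the single measured step touched a different group, so it gives no direct guide, and both numbers sit within the scatter of each other. The estimate for compound 3 is therefore 50000 nM, range 20000 nM to 120000 nM, which in this assay is expected as a 1.0-fold higher number from compound 2 to compound 3 (0.00 log units; within the scatter).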

Compound 3, half-maximal cytotoxic concentration: 97400 nM
For compound 3 the middle estimate is 1.9-fold (0.29 log units) below the measured one; the measured number falls inside the stated range.
By their numbers in this assay, from the lowest: compounds 2, 1 and 3 (each within the scatter of the next).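

In this assay the step to the 4-nitrophenyl group, on a saturated chain carbon bound to a saturated ring carbon, reads as a 2.0-fold higher number from compound 2 to compound 3 (0.29 log units; within the scatter) and as a 1.9-fold higher number from compound 1 to compound 3 (0.29 log units; within the scatter). All three aryl groups at this position thus stay within the scatter of each other, where the earlier pair covered only two of them. No supporting data on the cause accompany this result.

On these data alone, how the read-out behaves with an amine, a carboxylic acid or a longer chain at this position stays open. So does the effect of changes elsewhere on the shared core.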